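A few compounds are considered here, and "the series" means these few. Any claim that something is new, unique, unknown or untested is made for them only; others in the source may bear on it.

Three compounds built on the core of compound 1 `COc1nc2ccc(Br)cc2cc1C(c1ccccc1)n1cc(-c2ccccc2F)nn1` have been tested in an ADME assay on HEK293 cells (Homo sapiens) for cytotoxicity, read by sulforhodamine B assay, with a stated time of 48 h, tested at 10 uM; a lower number here means less inhibition, a higher number more inhibition at the concentration tested (going by the name of the read-out). Compound 1 gives 3.97% there; compound 2 `CCCCc1cn(C(c2ccccc2)c2cc3cc(Br)ccc3nc2OC)nn1` gives -3.47%; compound 3 `COc1nc2ccc(Br)cc2cc1C(c1ccccc1)n1cc(CCCCCO)nn1` gives 7.96%. Compound 3 holds the highest of the three numbers, although a number 4 percentage points higher from compound 1 to compound 3 (within the scatter) sits within the scatter and only a number 11.4 percentage points higher from compound 2 to compound 3 (beyond the scatter) lies beyond it. Compound 4 `COc1nc2ccc(Br)cc2cc1C(c1ccccc1)n1cc(CCCO)nn1` differs from compound 3 by hydroxy in place of 2-hydroxyethyl on a saturated chain carbon, three bonds along the chain from an aromatic carbon. Within the data shown here, the only measured step that bears on a hydroxyalkyl chain is the modest a number 11.4 percentage points higher from compound 2 to compound 3 (beyond the scatter), and the change to compound 4 removes part of that chain. A small downward step, if any, is expected: a number 3 percentage points lower from compound 3 to compound 4 (within the scatter). Compound 4 is therefore estimated at 5%, within a range from -5% to 15%.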

Compound 4, a percentage reported as inhibition, at one concentration (the size of the read-out at that concentration, not a potency): 27.4%
Compound 4: middle estimate off by 22.4 percentage points, on the low side; the measured number lies above the stated range.
By their numbers in this assay, from the lowest: compounds 2, 1 and 3 (each within the scatter of the next, the first and the last beyond it); then compound 4.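

In this assay, shortening the chain at this position from 5-hydroxypentyl to 3-hydroxypropyl, with the hydroxy kept, moves the number clearly (a number 19.4 percentage points higher from compound 3 to compound 4 (beyond the scatter)). The 3-hydroxypropyl chain also stands apart from butyl (a number 30.9 percentage points higher from compound 2 to compound 4 (beyond the scatter)) and from 2-fluorophenyl (a number 23.4 percentage points higher from compound 1 to compound 4 (beyond the scatter)), whereas the three earlier groups had spanned only a modest range. Nothing available accounts for this rise. The compounds shown leave open how 2-hydroxyethyl or 4-hydroxybutyl would read here. They also leave open whether an amine or a carboxylic acid at the chain end could stand in for the hydroxy.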